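Cytotoxicity on Vero Cells across a Small Amide Series

A few compounds are considered here, and "the series" means these few. Any claim that something is new, unique, unknown or untested is made for them only; others in the source may bear on it.

Compound 1, `CCCCc1nc(Cl)c(C2NC(=O)NC(C)=C2C(=O)Nc2ccccc2C)[nH]1`: in an ADME assay on Vero cells (Chlorocebus sabaeus) for cytotoxicity, read by MTT assay, with a stated time of 72 h (on this read-out higher numbers stand for weaker inhibition and lower numbers for stronger inhibition), compound 1 gives "not determined" (no result reported), so no number is reported for it there.
Compound 2, `CCCCc1nc(Cl)c(C2NC(=O)NC(C)=C2C(=O)Nc2ccc(F)cc2)[nH]1`: in this assay compound 2 gives > 10 ug/mL, which is a limit of the assay and not a number.

Among the compounds with values here, compound 1 thus stands without any single number in this assay; the only value shown is the limit of compound 2, and the limit of > 10 ug/mL in this assay, at which 1 of the 2 values shown sits, marks where that one reading sits. Compound 3, `CCCCc1nc(Cl)c(C2NC(=O)NC(C)=C2C(=O)Nc2ccc(Cl)cc2)[nH]1`, shares the core of compound 1 and differs from it in one place: 4-chlorophenyl in place of 2-methylphenyl on an amide-type nitrogen. Within the data shown here, no step between two measured compounds is available, so the size of the step from compound 1 to compound 3 in this assay cannot be read from a measured pair. Given that compound 2 carries a different substituted phenyl on the same amide-type nitrogen and reaches only > 10 ug/mL there, a reading beyond the scatter in either direction is not expected for compound 3, and a further limit rather than a number is the more likely outcome. For compound 3 in this assay the expected value is 15 ug/mL, with a range from 5 ug/mL to 40 ug/mL.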

Compound 3, half-maximal inhibitory concentration: 9.4 ug/mL
For compound 3 the middle estimate is 1.6-fold (0.20 log units) above the measured one, and the stated range covers the measured number.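

In this assay, within the data shown here, compound 3 gives 9.4 ug/mL, the first actual number for a substituted phenyl on the amide-type nitrogen, so this position can now be tied to a reading rather than only to the edge of the assay's range. Chloro in place of fluoro on an aromatic carbon gives an at least 1.0-fold lower number from compound 2 to compound 3 (0.02 log units; that floor lies within the scatter), and since that floor lies within the scatter, no real shift can be claimed for this change, though the true size of the step remains unknown. The reading of compound 2 remains a limit of the assay and not a number, and it is the only such reading in the series: the limit of > 10 ug/mL in this assay, at which 1 of the 3 values shown sits.

As far as these compounds go, the step from compound 1 to compound 3 cannot be read, so what the 2-methylphenyl group does relative to the 4-chlorophenyl group remains unknown. Also open, from the compounds shown here alone, is whether an amine or a carboxylic acid on the phenyl ring, or a longer chain on the shared core, would move the reading in this assay beyond the scatter.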